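This account rests on a few compounds, and the source may have more. Where it says the series, first, only, none or still open, it means among the compounds named here.

Measured in a functional assay on KM12 cells (Homo sapiens) for inhibition, read by sulforhodamine B assay, with a stated time of 48 h; on this read-out lower numbers stand for stronger inhibition of growth and higher numbers for weaker inhibition of growth:
compound 1 `O=C(Nc1cccc(-n2cc(-c3ccncc3)c(-c3ccc(Cl)c(O)c3)n2)c1)Nc1cccc(C(F)(F)F)c1`: 1330 nM
compound 2 `COc1cc(-c2nn(-c3cccc(NC(=O)c4cccc(C(F)(F)F)c4)c3)cc2-c2ccncc2)ccc1Cl`: 1660 nM

Compound 2, at 1660 nM, lies within the scatter of compound 1, at 1330 nM, so the two values give no ranking. These two compounds differ in more than one place, so their values do not isolate any single structural change. The next compound to be tested is compound 3 `COc1cc(-c2nn(-c3cccc(NC(=O)Nc4ccc(Cl)c(C(F)(F)F)c4)c3)cc2-c2ccncc2)ccc1Cl`. It differs from compound 2 as follows: (4-chloro-3-(trifluoromethyl)phenyl)amino in place of 3-(trifluoromethyl)phenyl on a carbonyl carbon. In words, (4-chloro-3-(trifluoromethyl)phenyl)amino stands in place of 3-(trifluoromethyl)phenyl on a carbonyl carbon. Going by the values given here, no measured pair here shows the size of this change, so the expectation is tentative. A moderate shift toward stronger inhibition of growth is expected, with an estimated step of a 2.8-fold lower number from compound 2 to compound 3 (0.44 log units; beyond the scatter) in this assay. The estimated value for compound 3 is 600 nM, with an expected range of 180 nM to 1800 nM.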

Compound 3, concentration for 50% growth inhibition: 1060 nM
Compound 3: the middle estimate sits 1.8-fold (0.25 log units) below what was measured; the measured number falls inside the stated range.
By their numbers in this assay, from the lowest: compounds 3, 1 and 2 (each within the scatter of the next).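

At the carbonyl carbon, (4-chloro-3-(trifluoromethyl)phenyl)amino in place of 3-(trifluoromethyl)phenyl gives a 1.6-fold lower number from compound 2 to compound 3 (0.19 log units; within the scatter) in this assay, so this position accepts the larger group with no readable change in growth inhibition. The entering group adds a nitrogen and a chlorine at once, and this single step does not separate the two; together they do not move the number beyond the scatter. Nothing available bears on why the number holds.

Still open, going by these compounds, is what the nitrogen or the chlorine does alone on this scaffold. Also open, on these data alone, is whether a quite different group on the carbonyl carbon, such as a morpholine or a phenyl carrying a carboxylic acid, would shift growth inhibition beyond the scatter.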